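This account rests on a few compounds, and the source may have more. Where it says the series, first, only, none or still open, it means among the compounds named here.

Measured compounds:

compound 1 `Nc1ccccc1NC(=O)/C=C/c1ccc(CSc2cccc(F)c2)cc1` — this assay: 50.7%
compound 2 `Nc1ccccc1NC(=O)c1ccc(CSc2cccc(F)c2)cc1` — this assay: 46.9%
compound 3 `Cc1ccc(SCc2ccc(/C=C/C(=O)Nc3ccccc3N)cc2)cc1` — this assay: 43.4%

All three values come from a functional assay on A549 cells (Homo sapiens) for inhibition, read by CCK-8 assay, with a stated time of 72 h, tested at 2 uM; a higher number here means more inhibition of growth at the concentration tested, a lower number less inhibition of growth. Compound 1 and compound 3 differ by 4-methylphenyl in place of 3-fluorophenyl on a sulfur; the step across that change was a number 7.3 percentage points lower from compound 1 to compound 3 (within the scatter), so the pair does not separate in this assay. Compound 2 carries a different core from compound 1; the difference between the two cores is not broken down here. In this assay compound 2 gives a number that lies within the scatter of both compound 1 and compound 3, so no order among the three can be stated.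

Compound 4 `Cc1ccc(SCc2ccc(C(=O)Nc3ccccc3N)cc2)cc1` has not yet been measured in this assay. It differs from compound 2 by 4-methylphenyl in place of 3-fluorophenyl on a sulfur, the same change that connects compound 1 and compound 3, and at the same place, a sulfur whose other neighbour is a saturated chain carbon. Compound 4 is expected to move by a number 4.9 percentage points lower from compound 2 to compound 4 (within the scatter), a step of about the same small size as the earlier one, because a number 7.3 percentage points lower from compound 1 to compound 3 (within the scatter) stayed within the scatter. Compound 4 is therefore estimated at 42%, with a range from 30% to 54%.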

Compound 4, percent growth inhibition at one concentration: 40.5%
Compound 4: middle estimate off by 1.5 percentage points, on the high side; low and high end bracket the measured number.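

In this assay, 4-methylphenyl in place of 3-fluorophenyl on a sulfur gives a number 6.4 percentage points lower from compound 2 to compound 4 (within the scatter). Set beside the earlier step, the change reads alike on the two cores: the same change on two cores in this assay, a number 7.3 percentage points lower (within the scatter) from compound 1 to compound 3 and a number 6.4 percentage points lower (within the scatter) from compound 2 to compound 4, 0.9 percentage points apart, within the scatter of two such steps. This shows that, on these two cores, the change stays within the scatter and the steps do not differ, but it does not show that the change has an effect of its own, or that a step large enough to rise above the scatter would carry from one core to the other in the same way.

The compounds shown leave open whether a phenyl ring bearing an amine or a carboxylic acid, or a longer chain in place of the aryl group on the sulfur, would give a step beyond the scatter. Also open, going by these compounds, is whether the same agreement between the cores would hold for any other change or on any other core.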